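The source may report more compounds than this note shows. Statements on the series, on what has been measured and on what is new or still open speak of the compounds shown alone.

Compounds measured so far:
compound 1 `COc1cccc(Cc2cn(C3CC3)c3c(F)c(-c4cc(C)nc(C)c4)c(F)cc3c2=O)c1`, 20000 nM
compound 2 `Cc1cc(-c2c(F)cc3c(=O)c(Cc4ccccc4O)cn(C4CC4)c3c2F)cc(C)n1`, 670 nM

In a functional assay on P388 cells (Mus musculus) for cytotoxicity (a lower number here means a stronger inhibitor, a higher number a weaker inhibitor), compound 2 holds the lowest of the two numbers, and its nearest neighbour is compound 1 with 20000 nM. Within the data shown here, the one recorded step, a 30-fold lower number from compound 1 to compound 2 (1.47 log units; beyond the scatter), shows that exchanging the aryl group on the saturated chain carbon moves the number a long way. Compound 3 `Cc1cc(-c2c(F)cc3c(=O)c(Cc4c[nH]cn4)cn(C4CC4)c3c2F)cc(C)n1` carries 1H-imidazol-4-yl in place of 2-hydroxyphenyl on a saturated chain carbon bound to an aromatic carbon. That step bears on it only loosely, so a modest shift is expected for compound 3, estimated as a 2.2-fold higher number from compound 2 to compound 3 (0.35 log units; beyond the scatter). Compound 3 is therefore expected at about 1500 nM, within 300 nM to 8000 nM.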

Compound 3, half-maximal inhibitory concentration: 390 nM
Compound 3: the middle estimate sits 3.8-fold (0.59 log units) above what was measured, and the stated range covers the measured number.
By their numbers in this assay, from the lowest: compounds 3 and 2 (each within the scatter of the next); then compound 1.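

In this assay the step of a 1.7-fold lower number from compound 2 to compound 3 (0.24 log units; within the scatter) shows that 1H-imidazol-4-yl can stand in for 2-hydroxyphenyl on this saturated chain carbon with no change beyond the scatter. The step of a 51-fold lower number from compound 1 to compound 3 (1.71 log units; beyond the scatter) shows that a low number here does not need an aromatic ring of carbon only. Nothing at hand accounts for these numbers. The compounds shown leave open how an aminomethyl group, a carboxylic acid or a longer chain would fare at this place, and whether an unsubstituted phenyl would match 2-hydroxyphenyl.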